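Replacing Methoxy with Nitro on the Aryl Arm

The compounds below may be only part of what the source reports. "The series", "measured", "known", "first", "only" and "open" are said of these compounds alone.

Two measured compounds anchor this comparison. Compound 1 `COc1ccc(-c2nn(-c3ccccc3)cc2/C=C/C(=O)c2ccc(OCc3ccccc3)c3c2OC(C)(C)C3)cc1` gives 7900 nM in a functional assay on PC-3 cells (Homo sapiens) for antiproliferative activity, read by MTT assay, with a stated time of 48 h (on this read-out lower numbers stand for stronger inhibition and higher numbers for weaker inhibition), the lowest of the two numbers available. Compound 2 `COc1ccc(/C=C/C(=O)c2ccc(O)c3c2OC(C)(C)C3)cc1` gives 48400 nM in this assay, a weaker result that lies beyond the usual scatter; compound 2 lacks much of the framework present in compound 1, so the two values show only that the larger molecule does better here. Compound 3 `CC1(C)Cc2c(OCc3ccccc3)ccc(C(=O)/C=C/c3cn(-c4ccccc4)nc3-c3ccc([N+](=O)[O-])cc3)c2O1` has not yet been measured. It differs from compound 1 in a single place: nitro in place of methoxy on an aromatic carbon, the methoxy giving way to a nitro group on an aromatic carbon. Going by the values given here, no measured pair shows this exchange, so its effect cannot be read from the data. The expected step is a 1.2-fold lower number from compound 1 to compound 3 (0.08 log units; within the scatter), which is not expected to exceed the scatter in either direction. Compound 3 is estimated to give 6500 nM in this assay, within a range from 2200 nM to 20000 nM.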

Compound 3, half-maximal inhibitory concentration: > 100000 nM
Compound 3 was reported as a limit; the forecaster's own chance of this, stated with the estimate: 3%; at least 15-fold (1.18 log units) between middle value and limit.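

In this assay, going from 4-methoxyphenyl to 4-nitrophenyl gives an at least 12-fold higher number from compound 1 to compound 3 (1.10 log units; beyond the scatter), so this single exchange on the aromatic carbon is enough to change the result well beyond the scatter. The earlier comparison could not show this, since compound 2 lacks much of the framework of compound 1 and no one place could be singled out. The value of compound 3 is a limit and not a number, so the step marks only a minimum: the limit of > 100000 nM in this assay, at which 1 of the 3 values shown sits.

With only methoxy and nitro shown at this place, it stays open whether an amine, a hydroxyl or a chlorine there would keep the activity of compound 1 or lose it as well. From the compounds shown here alone, it also stays open whether the same exchange on the aryl arm of compound 2 would have a like effect.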